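Aryl swap on the shared core, pyrrolidine series

A few compounds are considered here, and "the series" means these few. Any claim that something is new, unique, unknown or untested is made for them only; others in the source may bear on it.

Compound 1 `COc1cc2c(Oc3ccc(NC(=O)c4cc(-c5ccc(F)cc5)nc5ccccc45)cc3F)ccnc2cc1OCCCN1CCCCC1` gives 21 nM in a functional assay on NCI-H460 cells (Homo sapiens) for cytotoxicity, read by MTT assay, with a stated time of 72 h; on this read-out lower numbers stand for stronger inhibition and higher numbers for weaker inhibition. Compound 2 `COc1cc2c(Oc3ccc(NC(=O)c4cc(-c5ccc(Cl)c(Cl)c5)nc5ccccc45)cc3F)ccnc2cc1OCCCN1CCCCC1` gives 820 nM in this assay, the step of a 39-fold higher number from compound 1 to compound 2 (1.59 log units; beyond the scatter) being the large one in the set. Compound 3 `COc1cc2c(Oc3ccc(NC(=O)c4cc(-c5ccc(Cl)c(Cl)c5)nc5ccccc45)cc3F)ccnc2cc1OCCCN1CCCC1` gives 400 nM in this assay; it stands second highest of the three numbers, nearest compound 2 through the step of a 2.1-fold lower number from compound 2 to compound 3 (0.31 log units; beyond the scatter) and furthest from compound 1. Compound 4 `COc1cc2c(Oc3ccc(NC(=O)c4cc(-c5ccc(C)cc5)nc5ccccc45)cc3F)ccnc2cc1OCCCN1CCCC1` differs from compound 3 by 4-methylphenyl in place of 3,4-dichlorophenyl on an aromatic carbon. The step from compound 1 to compound 2 bears on this change, as it runs the other way, from 3,4-dichlorophenyl back to a smaller phenyl. A large drop in the number is therefore expected, a 13-fold lower number from compound 3 to compound 4 (1.12 log units; beyond the scatter), because the step of a 39-fold higher number from compound 1 to compound 2 (1.59 log units; beyond the scatter) was large. For compound 4 the estimate in this assay is 30 nM, range 8 nM to 120 nM.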

Compound 4, half-maximal inhibitory concentration: 240 nM
Compound 4: the middle estimate sits 8.0-fold (0.90 log units) below what was measured; measured number above the stated range.
By their numbers in this assay, from the lowest: compound 1; then compounds 4 and 3 (each within the scatter of the next); then compound 2.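

At the aromatic carbon next to the ring nitrogen, with pyrrolidin-1-yl on the chain, in this assay 4-methylphenyl in place of 3,4-dichlorophenyl gives a 1.7-fold lower number from compound 3 to compound 4 (0.22 log units; within the scatter) and no readable shift. The large 39-fold higher number from compound 1 to compound 2 (1.59 log units; beyond the scatter) at this position, read with piperidin-1-yl on the chain and 4-fluorophenyl as the partner, therefore does not carry over to this pair. No measurement at hand bears on this result.

Open, as far as these compounds go, is whether 4-fluorophenyl with pyrrolidin-1-yl on the chain would track compound 1, and how a morpholine on the chain would behave.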